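Swapping a thioether for an amine on a fused core

The compounds below may be only part of what the source reports. "The series", "measured", "known", "first", "only" and "open" are said of these compounds alone.

Compound 2: `CSc1nn2c(C)cc(C)nc2c1S(=O)(=O)c1ccc(O)cc1` gives 3.98 nM 
Compound 1: `CNc1nn2c(C)cc(C)nc2c1S(=O)(=O)c1ccc(OC)cc1` gives 9.55 nM

Both compounds were tested in a functional assay on HEK293 cells for antagonist activity at 5-hydroxytryptamine receptor 6 (Homo sapiens), read by cAMP accumulation, with a stated time of 2 h; on this read-out higher numbers stand for weaker inhibition and lower numbers for stronger inhibition. Compound 2 has the lower of the two numbers; compound 1 sits above it, and since the two structures differ in more than one place, only their two values can be compared, nothing about a single change. Compound 3, `CNc1nn2c(C)cc(C)nc2c1S(=O)(=O)c1ccc(O)cc1`, has not yet been measured. It comes from compound 2 by one change, (methylamino in place of methylsulfanyl on an aromatic carbon). Going by the values given here, no measured pair here isolates this change, so the expectation rests on the two values alone. Compound 1, which carries the methylamino group, stands somewhat higher than compound 2, so compound 3 is expected to give a number similar to compound 2 or a little higher, a step of a 1.5-fold higher number from compound 2 to compound 3 (0.18 log units; within the scatter) at most modest, possibly none beyond the usual scatter. Compound 3 is estimated at 6 nM, within 2 nM to 18 nM.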

Compound 3, inhibition constant: 2 nM
The estimate for compound 3 lay 3.0-fold (0.48 log units) above the measured number, within the range that was stated.
By their numbers in this assay, from the lowest: compounds 3 and 2 (each within the scatter of the next); then compound 1.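

Methylamino in place of methylsulfanyl on this aromatic carbon now has a measured pair of its own: a 2.0-fold lower number from compound 2 to compound 3 (0.30 log units; within the scatter), so the two groups cannot be told apart on this read-out. Going by these compounds alone, the single change on the oxygen can now be read as well, since hydrogen in place of methyl there gives a 4.8-fold lower number from compound 1 to compound 3 (0.68 log units; beyond the scatter), and of the two steps this is the only one that clears the scatter. Nothing measured here explains either step.

On these data alone, whether a plain amine, a dimethylamino group or an ethylamino chain on the same aromatic carbon would stay close to these values remains open. Also open, as far as these compounds go, is what an ethyl group or a longer chain on the oxygen would do to the number.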